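A few compounds are considered here, and "the series" means these few. Any claim that something is new, unique, unknown or untested is made for them only; others in the source may bear on it.

Two compounds of this series have a result in a functional assay on L1210 cells (Mus musculus); on this read-out lower numbers stand for stronger inhibition and higher numbers for weaker inhibition. Compound 1 `CCCCCc1cn([C@H]2C[C@H](O)[C@@H](CO)O2)c(=O)[nH]c1=O` gives 477 ug/mL, the only plain number shown. Compound 2 `CC(C)c1cn([C@H]2C[C@@H]3OP(=O)(O)OC[C@H]3O2)c(=O)[nH]c1=O` reaches only a limit of the assay rather than a number: in this assay compound 2 gives > 500 ug/mL, which is the limit of > 500 ug/mL in this assay, at which 1 of the 2 values shown sits. Compound 3 `CCCc1cn([C@H]2C[C@H](O)[C@@H](CO)O2)c(=O)[nH]c1=O` has not yet been measured in this assay. It differs from compound 1 in one place: hydrogen in place of ethyl on a saturated chain carbon, three bonds along the chain from an aromatic carbon. Going by the values given here, no measured step sets a size for this change, so compound 1 is the only anchor. The step from compound 1 is expected to be a 1.0-fold higher number from compound 1 to compound 3 (0.00 log units; within the scatter), none beyond the scatter. Compound 3 is therefore estimated at 480 ug/mL, between 240 ug/mL and 1000 ug/mL.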

Compound 3, concentration for 50% inhibition: > 500 ug/mL
Compound 3 was reported as a limit (the forecaster's own chance of this, stated with the estimate: 40%); middle value at least 1.0-fold (0.01 log units) away from the limit.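

In this assay compound 3 gives > 500 ug/mL, which is a limit and not a number. Shortening pentyl to propyl at this position gives an at least 1.0-fold higher number from compound 1 to compound 3 (0.02 log units; that floor lies within the scatter). The shorter chain brings no stronger inhibition into view, and how much weaker it may be cannot be told, because the read-out ends at a limit: the limit of > 500 ug/mL in this assay, at which 2 of the 3 values shown sit.

From the compounds shown here alone, whether a longer chain such as octyl, or an amine at the end of the pentyl chain, would give a clearly lower number stays open. Going by these compounds alone, with compound 1 as the only plain number, no trend along the chain can be drawn.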